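The compounds below may be only part of what the source reports. "The series", "measured", "known", "first", "only" and "open" are said of these compounds alone.

Compound 1 `CC1=CN([C@H]2C[C@H](O)[C@@H](COC(=O)C[C@@]3(C)C[C@@](C)(O)CO3)O2)C(=O)NC1` is the reference point for the step under study. In a functional assay on C8166 cells (Homo sapiens) for cytotoxicity (on this read-out lower numbers stand for higher toxicity in this test and higher numbers for lower toxicity in this test), compound 1 gives only a limit, > 500000 nM, and no number. The other measured members of the series give numbers: compound 2 `Cc1cn([C@H]2C[C@H](O[Si](C)(C)C(C)(C)C)[C@@H](COC(=O)CC3(C)CC(C)(O)CO3)O2)c(=O)[nH]c1=O` gives 200000 nM; 200000 nM (2 entries) in this assay, and compound 3 `CSCOC1(C)COC(C)(CC(=O)OC[C@@H]2C=C(O)[C@H](n3cnc4c(N)ncnc43)O2)C1` gives 400000 nM. Compound 1 therefore stands at the limit of > 500000 nM in this assay, at which 1 of the 3 values shown sits, the least toxic end of what has been seen so far.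

Compound 4 `Cc1cn([C@H]2C[C@H](O)[C@@H](COC(=O)C[C@@]3(C)C[C@@](C)(O)CO3)O2)c(=O)[nH]c1=O` differs from compound 1 in one place: a group of 9 heavy atoms (5 carbon, 2 nitrogen, 2 oxygen; one six-membered aromatic ring with 2 hetero atoms) in place of a group of 8 heavy atoms (5 carbon, 2 nitrogen, 1 oxygen; one six-membered non-aromatic ring with 2 hetero atoms), on a saturated ring carbon. Within the data shown here, no measured pair shows this change, so the step from compound 1 to compound 4 is expected to stay within the scatter, with no clear direction, as an at least 1.2-fold lower number from compound 1 to compound 4 (0.09 log units; that floor lies within the scatter). Compound 4 is estimated at 400000 nM in this assay, within 150000 nM to 1000000 nM.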

Compound 4, half-maximal cytotoxic concentration: > 1000000 nM
Compound 4 ended at the assay's limit (the forecaster's own chance of this, stated with the estimate: 50%); middle value at least 2.5-fold (0.39 log units) from the limit.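

In this assay compound 1 gives > 500000 nM, a limit. Compound 4 gives > 1000000 nM, also a limit. Among these compounds, no step between compound 1 and compound 4 can be read. The compounds shown leave open whether this group exchange changes the read-out at all.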